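A few compounds are considered here, and "the series" means these few. Any claim that something is new, unique, unknown or untested is made for them only; others in the source may bear on it.

Compound 1 `CC(C)N(Cc1cccc(OCCCCCC(=O)O)c1)C(=O)c1ccc(-c2ccoc2)cc1` gives in an ADME assay on HepG2 cells (Homo sapiens) for cytotoxicity, read by CellTiter-Glo and resazurin assay, with a stated time of 72 h (on this read-out higher numbers stand for an effect only at larger amounts of compound and lower numbers for an effect already at smaller amounts), only a limit, > 26000 nM. Compound 2 `COc1ccc(F)c(-c2ccc(C(=O)N(Cc3cccc(OCCCCCC(=O)O)c3)C(C)C)cc2)c1` gives in this assay likewise only a limit, > 26000 nM.

Both values sit at the same limit (the limit of > 26000 nM in this assay, at which 2 of the 2 values shown sit), so compound 2 stands at the edge of what this assay can report, and the step that the two limits leave unreadable from compound 1 to compound 2 cannot be read. Compound 3 `CC(C)N(Cc1cccc(OCCCCCC(=O)O)c1)C(=O)c1ccc(-c2cccc(F)c2)cc1` carries 3-fluorophenyl in place of 2-fluoro-5-methoxyphenyl on an aromatic carbon. Among the compounds with values here, the only measured step, from compound 1 to compound 2, is unreadable and gives no size to lean on. For compound 3 a step that the limit leaves unreadable from compound 2 to compound 3 of no size beyond the scatter is therefore expected. Compound 3 is estimated at 30000 nM, between 15000 nM and 80000 nM.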

Compound 3, half-maximal effective concentration: > 26000 nM
Compound 3: a limit, no number (the forecaster's own chance of this, stated with the estimate: 75%); the middle value lies beyond the limit too.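

Compound 1, compound 2 and compound 3 all give only a limit, so no step among them can be read: the limit of > 26000 nM in this assay, at which 3 of the 3 values shown sit.

As far as these compounds go, whether furan-3-yl, 2-fluoro-5-methoxyphenyl and 3-fluorophenyl differ at all in this assay stays open.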